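Phenoxy for cyclopentylamino on a shared pyrazolopyrimidine-type core

The source may report more compounds than this note shows. Statements on the series, on what has been measured and on what is new or still open speak of the compounds shown alone.

Compound 1 `O=C(NC1CC1)c1ccc(-c2cnn3c(NCC4CCOCC4)nc(NC4CCCC4)nc23)cc1` — 690 nM
Compound 2 `O=C(NC1CC1)c1ccc(-c2cnn3c(NCC4CCOCC4)nc(NC4CCCC4)nc23)cc1F` — 1400 nM

Of the compounds shown here, two have been measured in a functional assay on MDA-MB-231 cells (Homo sapiens) for antiproliferative activity; a higher number here means a weaker inhibitor of growth, a lower number a stronger inhibitor of growth. Compound 1 gives 690 nM, the lower of the two numbers; its nearest neighbour is compound 2, and the step of a 2.0-fold higher number from compound 1 to compound 2 (0.31 log units; beyond the scatter) is modest but beyond the scatter. Compound 3 `O=C(NC1CC1)c1ccc(-c2cnn3c(NCC4CCOCC4)nc(Oc4ccccc4)nc23)cc1` is not yet measured. It differs from compound 1 by phenoxy in place of cyclopentylamino on an aromatic carbon. Going by the values given here, the only measured step, a 2.0-fold higher number from compound 1 to compound 2 (0.31 log units; beyond the scatter), concerns a fluoro replacing hydrogen on the benzamide ring and does not touch the position changed here, so nothing in the data speaks to the size or direction of this change. Among the compounds with values here, the step of a 2.9-fold higher number from compound 1 to compound 3 (0.46 log units; beyond the scatter) is therefore an estimate resting on no measured precedent. Compound 3 is expected to give about 2000 nM, with a wide range from 400 nM to 10000 nM.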

Compound 3, concentration for 50% growth inhibition: 350 nM
Compound 3: middle estimate off by 5.7-fold (0.76 log units), on the high side, outside the stated range (below it).
By their numbers in this assay, from the lowest: compounds 3 and 1 (each within the scatter of the next); then compound 2.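

In this assay, replacing cyclopentylamino with phenoxy on the shared core gives a 2.0-fold lower number from compound 1 to compound 3 (0.29 log units; within the scatter), so compound 1 and compound 3 cannot be told apart in this read-out. This position, between two ring nitrogen atoms, therefore accepts either a five-membered non-aromatic ring joined through nitrogen or a six-membered aromatic ring joined through oxygen, and in this pair the hydrogen-bond donor of cyclopentylamino, absent from phenoxy, is not required to keep the number in the same range. No available measurement bears on why the two compounds read alike.

The compounds shown do not separate the linking atom from the ring, which phenylamino or cyclopentyloxy at this position would do. As far as these compounds go, whether a simple amine, a morpholine or a benzyloxy group would fit equally well also remains open.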